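A few compounds are considered here, and "the series" means these few. Any claim that something is new, unique, unknown or untested is made for them only; others in the source may bear on it.

Compound 1 `CCCCCC(=O)NCC(=O)N(C)c1ccc(Cl)cc1C(=O)c1ccccc1Cl`: 1.9 mg/kg
Compound 2 `CC(=O)NCC(=O)N(C)c1ccc(Cl)cc1C(=O)c1ccccc1Cl`: 2.3 mg/kg
Compound 3 `CN(C(=O)CNC(=O)CN1CCN(c2ccccc2)CC1)c1ccc(Cl)cc1C(=O)c1ccccc1Cl`: 75 mg/kg

In a functional assay on the whole organism for antagonist activity, with Mus musculus as the target (on this read-out higher numbers stand for an effect only at larger amounts of compound and lower numbers for an effect already at smaller amounts), compound 1 stands at the low end of the three numbers, within the scatter of compound 2. Compound 4 `CCCCCCCCCCCCCCCC(=O)NCC(=O)N(C)c1ccc(Cl)cc1C(=O)c1ccccc1Cl` lengthens the chain of compound 1: decyl in place of hydrogen on a saturated chain carbon, five bonds along the chain from a carbonyl carbon. Removing the butyl group changed little, a 1.2-fold higher number from compound 1 to compound 2 (0.08 log units; within the scatter). Placing 4-phenylpiperazin-1-yl on the same carbon gave large steps, a 39-fold higher number from compound 1 to compound 3 (1.60 log units; beyond the scatter) and a 33-fold higher number from compound 2 to compound 3 (1.51 log units; beyond the scatter). Among the measured compounds shown here, no measured compound carries a chain as long as that of compound 4, so the expectation is loose: a moderate move towards a higher number. The expected step is a 3.2-fold higher number from compound 1 to compound 4 (0.50 log units; beyond the scatter). Compound 4 is expected at 6 mg/kg, with an estimated range of 1.5 mg/kg to 30 mg/kg.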

Compound 4, dose for half-maximal effect: > 100 mg/kg
Compound 4: only a limit was reported; the forecaster's own chance of this, stated with the estimate: 15%; middle value at least 16-fold (1.22 log units) from the limit.
By their numbers in this assay, from the lowest: compounds 1 and 2 (each within the scatter of the next); then compound 3. At a limit, above all of these: compound 4.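

In this assay, the length of this chain does matter: the step of a 1.2-fold higher number from compound 1 to compound 2 (0.08 log units; within the scatter) stayed within the scatter, whereas decyl, five bonds along the chain from a carbonyl carbon, gives an at least 52-fold higher number from compound 1 to compound 4 (1.72 log units; beyond the scatter). The result for compound 4 is a limit and not a number: the limit of > 100 mg/kg in this assay, at which 1 of the 4 values shown sits. Among the compounds shown here, a plain carbon chain without a ring is therefore enough for a large step in this part of the molecule, which the earlier compounds did not show.

Where the change sets in between compound 1 and compound 4 stays open, for instance with an octyl chain. Also open, going by these compounds, is whether a long chain carrying a carboxylic acid or an amine would read the same.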